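Aryl urea series on a shared core: towards compound 4

The source may hold more compounds than are shown below. What is called first, only, known or untested is meant among the compounds shown, and "the series" means these compounds.

Measured so far:
- compound 1, `Cc1ccc(NC(=O)Nc2cccc(CNc3nccnc3Cl)c2)c(C)c1`, in a functional assay on HepG2 cells (Homo sapiens) for antiproliferative activity, read by MTT assay, with a stated time of 48 h (on this read-out lower numbers stand for stronger inhibition and higher numbers for weaker inhibition), compound 1 gives 9290 nM
- compound 2, `CS(=O)(=O)c1ccc(NC(=O)Nc2cccc(CNc3nccnc3Cl)c2)cc1`, in this assay compound 2 gives 15100 nM
- compound 3, `CCc1ccc(NC(=O)Nc2cccc(CNc3nccnc3Cl)c2)c(CC)c1`, in this assay compound 3 gives 10800 nM

Compound 1 holds the lowest of the three numbers in this assay, but its gap to compound 3 and its gap to compound 2 both fall inside the usual scatter of repeated measurements, so the three measured compounds cannot be ranked against one another on this read-out. All three share the same core and differ only in the group on the amide-type nitrogen whose other neighbour is the carbonyl carbon.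

Compound 4, `O=C(Nc1cccc(CNc2nccnc2Cl)c1)Nc1ccc(Cl)c(Cl)c1`, has not yet been measured in this assay. Compared with compound 1 the difference is 3,4-dichlorophenyl in place of 2,4-dimethylphenyl on an amide-type nitrogen. What leaves and what enters are of the same size, each with one six-membered aromatic ring of carbon only and neither carrying hydrogen-bond donors or acceptors.

Since the three measured substituents at this position all give numbers within the scatter of one another, the step from compound 1 to compound 4 is expected to be a 1.1-fold lower number from compound 1 to compound 4 (0.04 log units; within the scatter), that is, no change beyond the scatter in either direction. Compound 4 is therefore estimated at 8500 nM, with a range from 3000 nM to 22000 nM.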

Compound 4, half-maximal inhibitory concentration: 6170 nM
Estimate against measurement, compound 4: 1.4-fold (0.14 log units) above, within the range that was stated.
By their numbers in this assay, from the lowest: compounds 4, 1, 3 and 2 (each within the scatter of the next, the first and the last beyond it).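

In this assay the exchange of 2,4-dimethylphenyl for 3,4-dichlorophenyl on the amide-type nitrogen reads as a 1.5-fold lower number from compound 1 to compound 4 (0.18 log units; within the scatter) and so gives no change that can be told from the scatter, even though chlorine replaces both methyl groups and the ring moves to a different substitution pattern at an unchanged heavy-atom count. Among the compounds shown here, the new value does give the series its first separation at this position: compound 4 at 6170 nM and compound 2 at 15100 nM are the one pair among the four whose numbers lie beyond the scatter of each other, while each stays within the scatter of its nearest neighbour in the order. No measurement at hand bears on why the numbers fall as they do.

All four compounds carry a substituted phenyl group on this nitrogen, so it remains open whether a cyclohexyl group or an n-butyl chain there would stay among these numbers. The core is also the same throughout, which leaves open what an amine in place of its chlorine would do in this read-out.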